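A few compounds are considered here, and "the series" means these few. Any claim that something is new, unique, unknown or untested is made for them only; others in the source may bear on it.

Three compounds of the series have numbers in an ADME assay on microsomes from liver (Rattus norvegicus) for metabolic stability, read by LC-MS, using NADPH, with a stated time of 60 min, tested at 10 uM; a lower number here means that less of the compound is left, a higher number that more of the compound is left. Compound 1 `[O-][S+](CCNC1CCN(Cc2ccc(F)cc2)CC1)C(c1ccc(F)cc1)c1ccc(F)cc1` gives 95%, compound 2 `OC(Cc1ccccc1)CN1CCC(NCCSC(c2ccc(F)cc2)c2ccc(F)cc2)CC1` gives 74%, and compound 3 `[O-][S+](CCNC1CCN(CC(O)Cc2ccccc2)CC1)C(c1ccc(F)cc1)c1ccc(F)cc1` gives 22%. Compound 2 thus stands second highest of the three, below compound 1 and above compound 3, both gaps beyond the scatter. Compound 4 `O=C(c1ccc(F)cc1)N1CCC(NCCSC(c2ccc(F)cc2)c2ccc(F)cc2)CC1` is not yet measured; it differs from compound 2 by (4-fluorophenyl)carbonyl in place of 2-hydroxy-3-phenylpropyl on an amine nitrogen in a ring. For the measured compounds named here, the one measured step at this place, a number 73 percentage points lower from compound 1 to compound 3 (beyond the scatter), was large and ran from a 4-fluorophenyl to a 1-hydroxy-2-phenylethyl. The present change runs the other way, removing the 2-hydroxy-3-phenylpropyl, so compound 4 is expected to rise in this assay, a number 14 percentage points higher from compound 2 to compound 4 (beyond the scatter), with little room above compound 2. Compound 4 is estimated at 88%, range 68% to 99%.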

Compound 4, percent of the compound remaining: 24%
Compound 4: the middle estimate sits 64 percentage points above what was measured; measured number below the stated range.
By their numbers in this assay, from the lowest: compounds 3 and 4 (each within the scatter of the next); then compound 2; then compound 1.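

Replacing 2-hydroxy-3-phenylpropyl with (4-fluorophenyl)carbonyl on the ring amine nitrogen gives a large fall in this assay, a number 50 percentage points lower from compound 2 to compound 4 (beyond the scatter), on the core of compound 2. With a number 73 percentage points lower from compound 1 to compound 3 (beyond the scatter), the entry of a hydroxy-bearing chain also went with a lower number, so the loss of 2-hydroxy-3-phenylpropyl does not by itself go with a higher one. No measurement here explains the fall.

Going by these compounds, whether the carbonyl link or the fluorine on the entering ring matters stays open. A methylsulfonyl or a plain benzoyl on this nitrogen would help separate these.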